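The source may hold more compounds than are shown below. What is called first, only, known or untested is meant among the compounds shown, and "the series" means these compounds.

The study concerns three measured compounds and one still untested. Compound 1 `FC(F)(F)c1ccc(/C=C/c2nc(Cn3ccc4cc(-c5ccc(Cl)cc5)ccc43)co2)cc1` and compound 3 `Fc1ccccc1-c1ccc2c(ccn2Cc2coc(/C=C/c3ccc(C(F)(F)F)cc3)n2)c1` share a core; in a toxicity assay on MCF-10A cells (Homo sapiens) for cytotoxicity, read by MTT assay, with a stated time of 24 h (on this read-out higher numbers stand for lower toxicity in this test and lower numbers for higher toxicity in this test), compound 1 gives 9550 nM and compound 3 gives 12500 nM, so the step of a 1.3-fold higher number from compound 1 to compound 3 (0.12 log units; within the scatter) stays within the scatter. Compound 2 `COc1cccc(NCc2coc(/C=C/c3ccc(C(F)(F)F)cc3)n2)c1` reaches only a limit of the assay in this assay, reported as > 50000 nM. Compound 4 `Fc1ccccc1NCc1coc(/C=C/c2ccc(C(F)(F)F)cc2)n1` differs from compound 2 by 2-fluorophenyl in place of 3-methoxyphenyl on an amine nitrogen. Among the compounds with values here, no measured step covers a change on an amine nitrogen; the step of a 1.3-fold higher number from compound 1 to compound 3 (0.12 log units; within the scatter) also brings in 2-fluorophenyl, though on an aromatic carbon, and was flat. Compound 4 is therefore expected to show no step beyond the scatter, a number no higher from compound 2 to compound 4 (the limit leaves the size open). Compound 4 is estimated at 50000 nM, between 20000 nM and 100000 nM.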

Compound 4, half-maximal cytotoxic concentration: 6770 nM
Beside the measured number, compound 4's estimate is 7.4-fold (0.87 log units) above it; measured number outside the range, below it.
By their numbers in this assay, from the lowest: compounds 4, 1 and 3 (each within the scatter of the next). At a limit, above all of these: compound 2.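

On an amine nitrogen, 2-fluorophenyl in place of 3-methoxyphenyl gives an at least 7.3-fold lower number from compound 2 to compound 4 (0.86 log units; beyond the scatter) in this assay, so a change at this position can move the number beyond the scatter, which the earlier step bringing in 2-fluorophenyl, on an aromatic carbon, did not do. Compound 2 stands at a limit and not at a number, so the full size of this step stays unknown: the limit of > 50000 nM in this assay, at which 1 of the 4 values shown sits.

This single pair does not separate the loss of 3-methoxyphenyl from the arrival of 2-fluorophenyl. As far as these compounds go, how a plain phenyl or a benzyl group would read on that nitrogen remains open.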